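Trifluoromethyl for methyl on the urea-capped aryl ring

The source may report more compounds than this note shows. Statements on the series, on what has been measured and on what is new or still open speak of the compounds shown alone.

For the measured compounds named here, compound 2 `COc1cc2cc(Oc3ccc(NC(=O)Nc4ccc(C)cc4)cc3)c(C)nc2cc1OC` gives 102% in a functional assay on LOX IMVI cells (Homo sapiens) for inhibition, read by sulforhodamine B assay, with a stated time of 48 h, tested at 10 uM (a higher number here means a weaker effect of the compound at the concentration tested, a lower number a stronger effect), and stands highest of the two numbers measured, with compound 1 `COc1cc2cc(Oc3ccc(NC(=O)Nc4ccccc4)cc3)c(C)nc2cc1OC` at 82.1% as its only neighbour. Going by the values given here, the step of a number 19.9 percentage points higher from compound 1 to compound 2 (beyond the scatter) is the one measured step, and it concerns a methyl entering, not leaving. Compound 3 `COc1cc2cc(Oc3ccc(NC(=O)Nc4ccc(C(F)(F)F)cc4)cc3)c(C)nc2cc1OC` differs from compound 2 by trifluoromethyl in place of methyl on an aromatic carbon. Among the compounds with values here, no measured step bears on this exchange directly, so the expected step of a number 10 percentage points lower from compound 2 to compound 3 (within the scatter) is small and uncertain, with a wide range. Compound 3 is estimated at 92% in this assay, between 62% and 112%.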

Compound 3, a percentage reported as activity, at one concentration (the size of the read-out at that concentration, not a potency): 56.4%
Estimate against measurement, compound 3: 35.6 percentage points above, outside the stated range (below it).
By their numbers in this assay, from the lowest: compound 3; then compound 1; then compound 2.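

In this assay the change to trifluoromethyl gives a number 45.6 percentage points lower from compound 2 to compound 3 (beyond the scatter) and also a number 25.7 percentage points lower from compound 1 to compound 3 (beyond the scatter) while the earlier step with methyl ran the other way. This aromatic carbon therefore does not respond to every replacement of hydrogen alike: from compound 1, methyl and trifluoromethyl move the number in opposite directions. Nothing available explains this difference. The compounds shown leave open whether chlorine, a methoxy group or an amine at this carbon would follow methyl or trifluoromethyl, and whether trifluoromethyl would do the same elsewhere on the ring.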